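Piperidine to 3-methylpyrrolidine on the amide of compound 2

The source may hold more compounds than are shown below. What is called first, only, known or untested is meant among the compounds shown, and "the series" means these compounds.

Compound 1 `O=C(C1CCC(F)(F)CC1)N1CC(c2nc(-c3cccc(F)c3)no2)C1`: 520 nM
Compound 2 `O=C(N1CCCCC1)N1CC(c2nc(-c3cccc(Cl)c3)no2)C1`: 370 nM

In an assay on HEK293 cells for positive allosteric modulation of metabotropic glutamate receptor 5 (Homo sapiens), read by FLIPR (on this read-out lower numbers stand for an effect already at smaller amounts and higher numbers for an effect only at larger amounts of compound), compound 2 gives 370 nM, the lower of the two numbers, while compound 1 gives 520 nM, a gap that stays within the scatter. Compound 3 `CC1CCN(C(=O)N2CC(c3nc(-c4cccc(Cl)c4)no3)C2)C1` is the unmeasured partner of compound 2; the change is 3-methylpyrrolidin-1-yl in place of piperidin-1-yl on a carbonyl carbon. Going by the values given here, no measured pair shows this kind of change, so the expectation is a step no larger than the scatter, with no direction favoured. Compound 3 is therefore estimated at 420 nM, in a range from 150 nM to 1200 nM. The expected step is a 1.1-fold higher number from compound 2 to compound 3 (0.06 log units; within the scatter).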

Compound 3, half-maximal effective concentration: > 10000 nM
Compound 3: a limit, no number; the forecaster's own chance of this, stated with the estimate: 5%; middle value at least 23-fold (1.37 log units) away from the limit.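

In this assay compound 3 reads > 10000 nM, which is a limit of the assay and not a number. The step is an at least 27-fold higher number from compound 2 to compound 3 (1.43 log units; beyond the scatter). Going by these compounds alone, on this carbonyl carbon, 3-methylpyrrolidin-1-yl in place of piperidin-1-yl keeps the same heavy atoms but is far from a neutral exchange, so this position responds sharply to how those atoms are joined, which the earlier compounds did not show. Still open, going by these compounds, is whether the smaller ring or the methyl group carries this step; pyrrolidin-1-yl and 3-methylpiperidin-1-yl on the same carbonyl carbon would separate the two.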